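The compounds below may be only part of what the source reports. "The series", "measured", "known", "first", "only" and "open" are said of these compounds alone.

Compound 1 `COc1ccc2cc(C(C)(O)CCN(C)C)ccc2c1`: 38.8 nM
Compound 2 `COc1ccc2cc(C(C)CCN3CCCCC3)ccc2c1`: 1.29 nM

Among the compounds with values here, in an assay on liver for displacement of a labelled ligand from Sigma non-opioid intracellular receptor 1 (Rattus norvegicus) (a higher number here means a weaker inhibitor, a lower number a stronger inhibitor), compound 2 gives 1.29 nM, the lower of the two numbers, and compound 1 gives 38.8 nM, a gap beyond the scatter; the two structures differ in more than one place, so no single step links them. Compound 3 `COc1ccc2cc(C(C)(O)CCN3CCCCC3)ccc2c1` has not yet been measured. It differs from compound 2 by hydroxy in place of hydrogen on a saturated chain carbon bound to an aromatic carbon and two saturated chain carbons. Compound 1 also carries a hydroxy at that chain carbon and gives 38.8 nM. A modest step toward a higher number is expected, a 6.2-fold higher number from compound 2 to compound 3 (0.79 log units; beyond the scatter), in this assay. Compound 3 is estimated at 8 nM, between 2 nM and 40 nM.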

Compound 3, inhibition constant: 10.4 nM
Compound 3: middle estimate off by 1.3-fold (0.11 log units), on the low side; low and high end bracket the measured number.
By their numbers in this assay, from the lowest: compound 2; then compound 3; then compound 1.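

In this assay, the effect of the hydroxy on this chain carbon can now be read on its own: putting it in place of hydrogen gives an 8.1-fold higher number from compound 2 to compound 3 (0.91 log units; beyond the scatter). With that hydroxy kept, piperidin-1-yl in place of dimethylamino gives a 3.7-fold lower number from compound 1 to compound 3 (0.57 log units; beyond the scatter), so the amine group also changes the number, and in the opposite direction. No measured evidence here explains either step. Still open, on these data alone, is how a fluorine or a methoxy on this chain carbon would compare with hydroxy. Also open, as far as these compounds go, is whether morpholin-4-yl in place of piperidin-1-yl would hold the lower number.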